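Trimming the sulfonamide nitrogen down to a bare methyl

This account rests on a few compounds, and the source may have more. Where it says the series, first, only, none or still open, it means among the compounds named here.

Compound 1, `Cc1ccc(S(=O)(=O)N2CCN(C)CC2)cc1C#Cc1cc(Cl)ccc1OCC(=O)O`: 21 nM
Compound 2, `Cc1ccc(S(=O)(=O)N2CCCCC2C)cc1C#Cc1cc(Cl)ccc1OCC(=O)O`: 1.9 nM
Compound 3, `Cc1ccc(S(=O)(=O)N(C)C)cc1C#Cc1cc(Cl)ccc1OCC(=O)O`: 5 nM

In an assay on CHO cells for displacement of a labelled ligand from prostaglandin D2 receptor 2 (Homo sapiens), read by scintillation counting (on this read-out higher numbers stand for weaker inhibition and lower numbers for stronger inhibition), compound 3 sits second highest of the three numbers. Its nearest neighbour is one step away: a 2.6-fold higher number from compound 2 to compound 3 (0.42 log units; beyond the scatter). The furthest is the other way: a 4.2-fold lower number from compound 1 to compound 3 (0.62 log units; beyond the scatter). Both steps swap one amine for another on the sulfonyl sulfur, and the size of the amine moved the number in each case. Compound 4, `Cc1ccc(S(C)(=O)=O)cc1C#Cc1cc(Cl)ccc1OCC(=O)O`, goes one step further: methyl in place of dimethylamino on a sulfonyl sulfur. Among the measured compounds shown here, no measured step removes the nitrogen altogether, so the bearing of the earlier steps is indirect. With the amine made still smaller, a modest rise in the number is expected. Compound 4 is therefore estimated at 12 nM, with a range of 3 nM to 50 nM. That expected change would read a 2.4-fold higher number from compound 3 to compound 4 (0.38 log units; beyond the scatter).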

Compound 4, inhibition constant: 5 nM
Compound 4: middle estimate off by 2.4-fold (0.38 log units), on the high side, within the range that was stated.
By their numbers in this assay, from the lowest: compound 2; then compounds 3 and 4 (each within the scatter of the next); then compound 1.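

Taking the nitrogen off the sulfonyl sulfur leaves the number in place (no change at the digits printed from compound 3 to compound 4 (within the scatter)), so here a methyl can stand in for dimethylamino without a measurable loss. Compound 4 therefore keeps the same gaps to the two compounds with larger amines (a 2.6-fold higher number from compound 2 to compound 4 (0.42 log units; beyond the scatter); a 4.2-fold lower number from compound 1 to compound 4 (0.62 log units; beyond the scatter)), which shows that this position does not need an amine for binding in the low nanomolar range. No measurement shown explains why the nitrogen can go.

On these data alone, whether ethyl, a longer chain, or a bare amino group on the same sulfur would hold the number stays open.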